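The source may hold more compounds than are shown below. What is called first, only, known or untested is meant among the compounds shown, and "the series" means these compounds.

In a functional assay on the whole organism with Rattus norvegicus as the target (on this read-out lower numbers stand for an effect already at smaller amounts and higher numbers for an effect only at larger amounts of compound), three compounds that share one core and differ only in the group on an amide-type nitrogen have been measured. Compound 1 (`CSc1nc(C)nc(SC)c1NC(=O)N(Cc1ccc(Oc2ccc(F)cc2)cc1)C1CCCCCC1`) gives 0.45 mg/kg, compound 2 (`COc1cc(C)nc(OC)c1NC(=O)N(Cc1ccc(Oc2ccc(F)cc2)cc1)C1CCCCCC1`) gives 4.5 mg/kg and compound 3 (`CSc1cc(C)nc(Cl)c1NC(=O)N(Cc1ccc(Oc2ccc(F)cc2)cc1)C1CCCCCC1`) gives 0.17 mg/kg, the lowest of the three numbers. Compound 4 (`CSc1nc(C)cc(Cl)c1NC(=O)N(Cc1ccc(Oc2ccc(F)cc2)cc1)C1CCCCCC1`) has the same atoms as compound 3, joined differently: a group of 10 heavy atoms (7 carbon, 1 nitrogen, 1 sulfur, 1 chlorine; one six-membered aromatic ring with 1 hetero atom) in place of a group of 10 heavy atoms (7 carbon, 1 nitrogen, 1 sulfur, 1 chlorine; one six-membered aromatic ring with 1 hetero atom), on an amide-type nitrogen. Among the measured compounds shown here, no measured step isolates such a rearrangement, so the evidence is indirect. The closest comparison is the modest 2.6-fold lower number from compound 1 to compound 3 (0.42 log units; beyond the scatter), as compound 1 also carries sulfur in this group. The large 26-fold lower number from compound 2 to compound 3 (1.42 log units; beyond the scatter) and the modest 10-fold higher number from compound 1 to compound 2 (1.00 log units; beyond the scatter) both involve compound 2, whose group holds oxygen, and compound 4 has none. They therefore bear on it less and show mainly how far this read-out can move when the group changes. With sulfur and chlorine both kept, a shift of the size seen for compound 2 is not expected. Since compound 3 already stands lowest at 0.17 mg/kg, any drift is expected to be upward, probably not beyond the scatter. The expected step is a 1.8-fold higher number from compound 3 to compound 4 (0.25 log units; within the scatter). Compound 4 is estimated at 0.3 mg/kg, with an expected range from 0.09 mg/kg to 1 mg/kg.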

Compound 4, dose for half-maximal effect: > 1 mg/kg
Compound 4 gave a limit, no number (the forecaster's own chance of this, stated with the estimate: 3%); at least 3.3-fold (0.52 log units) between middle value and limit.
By their numbers in this assay, from the lowest: compound 3; then compound 1; then compound 2.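

In this assay compound 4 gives > 1 mg/kg, which is a limit of the assay and not a number. Rearranging the same atoms within the group on the amide-type nitrogen, with nothing added or lost, is enough to give an at least 5.8-fold higher number from compound 3 to compound 4 (0.76 log units; beyond the scatter), so at this position the arrangement of the atoms matters and not only which atoms are present, something the earlier compounds could not show, as their groups all differ in composition. The comparison with the other group that holds sulfur points the same way, with an at least 2.2-fold higher number from compound 1 to compound 4 (0.34 log units; beyond the scatter), while the step from compound 2 to compound 4 cannot be read.

The compounds shown leave open how far compound 4 lies beyond its limit, and so where it stands against compound 2. From the compounds shown here alone, it is also open whether a group carrying an amine or a nitrile in place of the chlorine would respond to the same rearrangement as strongly, and which of the moved atoms accounts for the step.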